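The compounds below may be only part of what the source reports. "The series", "measured", "known", "first", "only" and "open" are said of these compounds alone.

Compound 1 `CCN1CCc2nc(C#Cc3ccccc3)sc2C1`: in an assay on HEK293 cells for positive allosteric modulation of metabotropic glutamate receptor 5 (Homo sapiens), read by FLIPR, with a stated time of 1 h (on this read-out higher numbers stand for an effect only at larger amounts of compound and lower numbers for an effect already at smaller amounts), compound 1 reaches only the assay limit > 10000 nM, which is a limit rather than a number.
Compound 2 `CC1CC1C(=O)N1CCc2nc(C#Cc3ccccc3)sc2C1`: compound 2 gives 9.4 nM.
Compound 3 `O=C(C1CC(F)C1)N1CCc2nc(C#Cc3ccccc3)sc2C1`: compound 3 gives 85 nM.

Compound 3 therefore holds the highest of the two real numbers, with compound 2 sitting a 9.0-fold higher number from compound 2 to compound 3 (0.96 log units; beyond the scatter). Compound 4 `CC(C)S(=O)(=O)N1CCc2nc(C#Cc3ccccc3)sc2C1` differs from compound 3 in one place: isopropylsulfonyl in place of (3-fluorocyclobutyl)carbonyl on an amine nitrogen in a ring. Going by the values given here, the steps that bear on this are those from the ethyl group to an acyl group, an at least 1000-fold lower number from compound 1 to compound 2 (3.02 log units; beyond the scatter) and an at least 110-fold lower number from compound 1 to compound 3 (2.07 log units; beyond the scatter), both large, so the group on this ring nitrogen matters strongly in this assay. Among the compounds with values here, an isopropylsulfonyl is a new kind of group here, and no measured step sets its size; the two acyl compounds differ only by a 9.0-fold higher number from compound 2 to compound 3 (0.96 log units; beyond the scatter). Compound 4 is expected to stay close to compound 3, a 1.4-fold higher number from compound 3 to compound 4 (0.15 log units; within the scatter), with wide uncertainty. The estimate for compound 4 is 120 nM, ranging from 20 nM to 900 nM.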

Compound 4, half-maximal effective concentration: > 10000 nM
Compound 4 ended at the assay's limit; the forecaster's own chance of this, stated with the estimate: 12%; at least 83-fold (1.92 log units) between middle value and limit.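

In this assay, replacing the acyl group on this ring nitrogen with isopropylsulfonyl matters far more than exchanging one acyl group for another: an at least 110-fold higher number from compound 3 to compound 4 (2.07 log units; beyond the scatter) and an at least 1000-fold higher number from compound 2 to compound 4 (3.02 log units; beyond the scatter), against only a 9.0-fold higher number from compound 2 to compound 3 (0.96 log units; beyond the scatter). Among these four compounds, the real numbers belong only to those with a carbonyl on this nitrogen, so replacing ethyl is not enough by itself. Compound 4 gives a limit, not a number: the limit of > 10000 nM in this assay, at which 2 of the 4 values shown sit.

The step from compound 1 to compound 4 cannot be read, as both ends are limits. Going by these compounds, whether a smaller methylsulfonyl or a simple acetyl on this nitrogen would follow compound 4 or compound 2 remains open.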